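Acetyl to Dimethylamino at a Low Screening Concentration

The source may hold more compounds than are shown below. What is called first, only, known or untested is meant among the compounds shown, and "the series" means these compounds.

Measured so far:
Compound 1 `COc1cc(C)cc(-c2c(-c3ccnc(-c4ccc(C(C)=O)cc4)c3)cnn2CC#N)c1` gives 96% in a functional assay on SF-268 cells (Homo sapiens) for cytotoxicity, read by sulforhodamine B assay, with a stated time of 48 h, tested at 0.01 uM; a higher number here means a weaker effect of the compound at the concentration tested, a lower number a stronger effect.
Compound 2 `COc1cc(C)cc(-c2nn(CC#N)cc2-c2ccc(-c3cccc(C(C)=O)c3)nc2)c1` gives 94% in this assay.

The number for compound 1 and the number for compound 2 lie within the usual scatter of each other, so compound 1 cannot be told apart from compound 2, and both show hardly any effect at this concentration. Compound 3 `COc1cc(C)cc(-c2c(-c3ccnc(-c4ccc(N(C)C)cc4)c3)cnn2CC#N)c1` differs from compound 1 in one place: dimethylamino in place of acetyl on an aromatic carbon. Among the measured compounds shown here, no step between measured compounds speaks to this change, so the expected step in this assay is none beyond the scatter, anchored on compound 1 at 96%. Compound 3 is expected to give 94%, with a range from 80% to 105%. The expected step of a number 2 percentage points lower from compound 1 to compound 3 (within the scatter) is accordingly small.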

Compound 3, a percentage reported as activity, at one concentration (the size of the read-out at that concentration, not a potency): 29%
Beside the measured number, compound 3's estimate is 65 percentage points above it; the whole stated range lies above it.
By their numbers in this assay, from the lowest: compound 3; then compounds 2 and 1 (each within the scatter of the next).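

Putting dimethylamino in place of acetyl on this aromatic carbon gives a number 67 percentage points lower from compound 1 to compound 3 (beyond the scatter) in this assay, so this position clearly matters to the effect at this low concentration. The two groups match in heavy-atom count and net charge, yet the results are far apart. Nothing available here explains why this change has so large an effect.

As far as these compounds go, it remains open whether a plain amino group or a carboxylic acid at this place would behave like dimethylamino. From the compounds shown here alone, it is also open whether the same change would have a similar effect on the core of compound 2.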